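This account rests on a few compounds, and the source may have more. Where it says the series, first, only, none or still open, it means among the compounds named here.

Measured in an ADME assay on MT4 cells (Homo sapiens) for cytotoxicity, read by MTT assay; a higher number here means that more compound is tolerated, a lower number that less compound is tolerated:
- compound 1 `O=C(CSc1nc(Cc2c(F)cccc2F)cc(=O)[nH]1)c1ccc([N+](=O)[O-])cc1`: 22000 nM
- compound 2 `O=C(CSc1nc(Cc2c(Cl)cccc2Cl)cc(=O)[nH]1)c1ccccc1`: > 12000 nM (a limit)
- compound 3 `O=C(CSc1nc(Cc2c(Cl)cccc2Cl)cc(=O)[nH]1)c1ccc(F)cc1`: > 59000 nM (a limit)

In this assay, compound 3 has no number, only the limit > 59000 nM. Compound 2 is likewise known only by a limit, > 12000 nM. Within the data shown here, compound 1 gives the only true number, 22000 nM.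

Compound 4 `COc1ccc(C(=O)CSc2nc(Cc3c(Cl)cccc3Cl)cc(=O)[nH]2)cc1` has methoxy in place of fluoro on an aromatic carbon, para to a large group, so 4-fluorophenyl becomes 4-methoxyphenyl: methoxy in place of fluoro on an aromatic carbon.

Among the measured compounds shown here, the one measured step at this place is a step that the two limits leave unreadable from compound 2 to compound 3, and it gives no usable size. For the measured compounds named here, no measured step covers the exchange of fluoro for methoxy, so no step beyond the scatter is expected in this assay and no direction can be assigned. The expected change is an at least 1.1-fold lower number from compound 3 to compound 4 (0.07 log units; that floor lies within the scatter), and the assay may again report only a limit. Compound 4 is estimated at 50000 nM, with an expected range from 15000 nM to 120000 nM.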

Compound 4, half-maximal cytotoxic concentration: > 11000 nM
Compound 4 gave a limit, no number (the forecaster's own chance of this, stated with the estimate: 55%); the middle value is on the limit's open side.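

Among these compounds, compound 2, compound 3 and compound 4 are known only by limits in this assay, and no step among them can be read. Going by these compounds, it remains open whether hydrogen, fluoro or methoxy on that aromatic carbon changes the tolerated concentration at all, and in which direction.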